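The compounds below may be only part of what the source reports. "The series", "measured", "known", "first", "only" and "open" are said of these compounds alone.

Measured compounds in a functional assay on NCI-H322M cells (Homo sapiens) for cytotoxicity, read by sulforhodamine B assay, with a stated time of 48 h, tested at 1 uM; on this read-out higher numbers stand for a weaker effect at the one concentration tested and lower numbers for a stronger effect:

Compound 1 `COc1ccc(-c2cc(/C=C/C(=O)c3ccc(N)cc3)[nH]n2)cc1` gives 69%.
Compound 2 `COc1cc(-c2cc(/C=C/C(=O)c3ccc(N)cc3)[nH]n2)cc(OC)c1OC` gives 94%.
Compound 3 `COc1cc(-c2cc(/C=C/C(=O)c3ccc(Cl)c(Cl)c3)[nH]n2)cc(OC)c1OC` gives 94%.

Compound 3 stands level with compound 2, and together these two show the highest readings of the three, which in this assay means the weakest effect. Compound 1 lies a good way lower than both, beyond the usual scatter, so it alone shows a clearer effect at the single concentration tested.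

Compound 4 `COc1cc(-c2cc(/C=C/C(=O)c3ccc(F)c(F)c3)[nH]n2)cc(OC)c1OC` has not yet been measured. It differs from compound 3 in one place: 3,4-difluorophenyl in place of 3,4-dichlorophenyl on a carbonyl carbon. Both groups sit on the same carbonyl carbon and are of the same size, differing only in which halogen they carry.

One measured step speaks to this position. The change no change at the digits printed from compound 2 to compound 3 (within the scatter) swapped a 4-aminophenyl for a 3,4-dichlorophenyl on that carbonyl carbon and produced nothing beyond the scatter. That step suggests the assay is not very sensitive to what hangs on this carbonyl carbon, at least within the compounds seen so far. The move from chlorine to fluorine is a smaller change than that one, so the expectation is a step of about a number 2 percentage points lower from compound 3 to compound 4 (within the scatter), that is, none beyond the scatter. Compound 4 is therefore estimated at 92%, with a likely range from 78% to 104%.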

Compound 4, a percentage reported as activity, at one concentration (the size of the read-out at that concentration, not a potency): 86%
Compound 4: middle estimate off by 6 percentage points, on the high side; the range from low to high includes it.
By their numbers in this assay, from the lowest: compound 1; then compounds 4, 2 and 3 (each within the scatter of the next).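

In this assay, replacing the 3,4-dichlorophenyl on the carbonyl carbon with 3,4-difluorophenyl gives a number 8 percentage points lower from compound 3 to compound 4 (within the scatter), so exchanging one halogen pair for the other does not move the reading past the usual scatter. Against the 4-aminophenyl group, the 3,4-difluorophenyl gives a number 8 percentage points lower from compound 2 to compound 4 (within the scatter), which means that all three groups tried at this position on the shared core now read alike. Nothing available explains this lack of separation.

The compounds shown leave open whether a phenyl ring carrying a carboxylic acid, or an open alkyl chain in place of the ring, would move the reading beyond the scatter at this carbonyl carbon. Going by these compounds, it also remains open whether 3,4-difluorophenyl would read the same on the core of compound 1.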